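Methoxy in place of amino: expectation for compound 3

The source may report more compounds than this note shows. Statements on the series, on what has been measured and on what is new or still open speak of the compounds shown alone.

In a functional assay on A549 cells (Homo sapiens) for cytotoxicity, read by MTT assay, with a stated time of 48 h (a higher number here means a weaker inhibitor, a lower number a stronger inhibitor), compound 1 `COc1ccc(OC)c(C2=NOC(COc3ccc(-c4nnnn4-c4cc(OC)c(OC)c(OC)c4)cc3N)C2)c1` gives 1930 nM and compound 2 `COc1ccc(C2=NOC(COc3ccc(-c4nnnn4-c4cc(OC)c(OC)c(OC)c4)cc3N)C2)cc1N` gives 2080 nM. These two values lie within the scatter of each other, so compound 2 stands level with compound 1 and no order can be read between them.

Compound 3 `COc1ccc(C2=NOC(COc3ccc(-c4nnnn4-c4cc(OC)c(OC)c(OC)c4)cc3N)C2)cc1OC` is reached from compound 2 by one change: methoxy in place of amino on an aromatic carbon. This is methoxy in place of amino on an aromatic carbon, ortho to a methoxy group and meta to a large group, and it turns 3-amino-4-methoxyphenyl into 3,4-dimethoxyphenyl.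

Among the measured compounds shown here, the only measured step that bears on this is a 1.1-fold higher number from compound 1 to compound 2 (0.03 log units; within the scatter). For the measured compounds named here, that step is not the same exchange, and no measured pair isolates amino against methoxy at this place, so the evidence is indirect and thin. Even so, it gives no reason to expect a shift in this assay.

The expected result is a 1.0-fold lower number from compound 2 to compound 3 (0.02 log units; within the scatter), which is no step beyond the scatter. For compound 3 the estimated value is 2000 nM, with an expected range of 800 nM to 5000 nM.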

Compound 3, half-maximal inhibitory concentration: 2520 nM
Compound 3: middle estimate off by 1.3-fold (0.10 log units), on the low side; the range from low to high includes it.
By their numbers in this assay, from the lowest: compounds 1, 2 and 3 (each within the scatter of the next).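

In this assay, among the compounds shown here, the amino group of the 3-amino-4-methoxyphenyl group gives way to methoxy with no step beyond the scatter (a 1.2-fold higher number from compound 2 to compound 3 (0.08 log units; within the scatter)), which is the first reading of this single exchange, on an aromatic carbon ortho to a methoxy group. The earlier step changed the whole substitution of this ring at once, whereas this one isolates amino against methoxy, and the read-out does not separate the two groups. The 3,4-dimethoxyphenyl group also stands level with the 2,5-dimethoxyphenyl group (a 1.3-fold higher number from compound 1 to compound 3 (0.12 log units; within the scatter)), and nothing measured here speaks to why the three compounds sit together.

Going by these compounds, since all three compounds lie within the scatter of one another, it remains open whether this position can move the read-out at all, and a hydroxyl, a carboxylic acid or a longer alkoxy chain in place of the methoxy group would test that more sharply. On these data alone, the second amino group, shared by all three compounds, also stays untested, so what a hydrogen or a methoxy group would do there is unknown.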